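The source may report more compounds than this note shows. Statements on the series, on what has been measured and on what is new or still open speak of the compounds shown alone.

Measured so far in an ADME assay on HEK293 cells (Homo sapiens) for cytotoxicity, with a stated time of 72 h; a lower number here means that less compound is needed, a higher number that more compound is needed for the effect:
compound 1 `C=C[C@@](C)(/C=C/c1ccc(O)c(/C=C/C#N)c1)CCC=C(C)C`: > 36600 nM (a limit)
compound 2 `C=C[C@@](C)(/C=C/c1ccc(O)c(/C=C/C(=O)O)c1)CCC=C(C)C`: > 36600 nM (a limit)
compound 3 `C=C[C@@](C)(/C=C/c1ccc(O)c(/C=C/c2ccc(Cl)cc2)c1)CCC=C(C)C`: > 36600 nM (a limit)

Compound 3 stands at > 36600 nM as a limit of the assay and not as a number. Going by the values given here, the series offers only one reading so far, (the limit of > 36600 nM in this assay, at which 3 of the 3 values shown sit), so compound 3 cannot be ranked against the other two.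

The next compound is compound 4 `C=C[C@@](C)(/C=C/c1ccc(O)c(/C=C/c2ccc(Cl)c(Cl)c2)c1)CCC=C(C)C`, and the change is chloro in place of hydrogen on an aromatic carbon, which takes 4-chlorophenyl to 3,4-dichlorophenyl.

The nearest evidence comes from the two measured changes that bring in the 4-chlorophenyl group, a step that the two limits leave unreadable from compound 1 to compound 3 and a step that the two limits leave unreadable from compound 2 to compound 3, along with a step that the two limits leave unreadable from compound 1 to compound 2 as the remaining comparison. None of these has a readable size, and none adds a second chloro to the aromatic ring, so they give no direction for the new change.

In this assay the expected change is therefore none beyond the scatter, and the estimate means a step that the limit leaves unreadable from compound 3 to compound 4 as the expected step. The most likely outcome is that compound 4 also reports only a limit.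

For compound 4 the estimated value is 40000 nM in the middle, with an expected range from 18000 nM to 80000 nM as its ends.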

Compound 4, half-maximal effective concentration: > 36600 nM
Compound 4 ended at the assay's limit (the forecaster's own chance of this, stated with the estimate: 75%); the middle value is on the limit's open side.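

In this assay compound 4 gives > 36600 nM, a limit of the assay and not a number. The steps joining compound 4 to compound 1, compound 2 and compound 3 therefore cannot be read: the limit of > 36600 nM in this assay, at which 4 of the 4 values shown sit.

The compounds shown leave open where any of the four truly lies past this limit, and whether chloro in place of hydrogen on the aromatic carbon shifts the value at all.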